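Sphingolipid-type series: amine variation at the side chain

The source may hold more compounds than are shown below. What is called first, only, known or untested is meant among the compounds shown, and "the series" means these compounds.

Measured so far in a functional assay on A549 cells (Homo sapiens) for antiproliferative activity, read by sulforhodamine B assay, with a stated time of 48 h, tested at 10 uM; on this read-out higher numbers stand for more inhibition at the one concentration tested (going by the name of the read-out) and lower numbers for less inhibition:
compound 1 `CCCCCCCCCCCCCC[C@H](O)[C@H](CO[Si](c1ccccc1)(c1ccccc1)C(C)(C)C)NC(=O)OC(C)(C)C`: 14.6%
compound 2 `CCCCCCCCCCCCCC[C@H](OCOC)[C@H](CN(CC)CC)NC(=O)OC(C)(C)C`: 27.5%

Two compounds carry numbers in this assay. Compound 2 stands highest of the two, and its nearest neighbour, compound 1, lies lower by a gap that is beyond the usual scatter. Among the measured compounds shown here, the two differ in several places at once, so no single step between them is counted; what their values show is only that compound 2 gives the larger inhibition.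

Compound 3 `CCCCCCCCCCCCCC[C@H](OCOC)[C@H](CN1CCCCC1)NC(=O)OC(C)(C)C` is the next member and has not yet been measured. It follows from compound 2 by one change: piperidin-1-yl in place of diethylamino on a saturated chain carbon, two bonds along the chain from an amide-type nitrogen. The amine stays tertiary and the rest of the molecule is unchanged. For the measured compounds named here, there is no measured pair that isolates this change, so nothing in the data fixes its size or direction. The expectation for the step from compound 2 to compound 3 is therefore a small one, a number 2.5 percentage points higher from compound 2 to compound 3 (within the scatter), not beyond the scatter in either direction. In this assay compound 3 is accordingly estimated at 30%, with a range from 15% to 45%.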

Compound 3, a percentage reported as inhibition, at one concentration (the size of the read-out at that concentration, not a potency): 19%
Compound 3: the middle estimate sits 11 percentage points above what was measured; the range from low to high includes it.
By their numbers in this assay, from the lowest: compounds 1, 3 and 2 (each within the scatter of the next, the first and the last beyond it).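

In this assay, among the compounds shown here, the exchange of diethylamino for piperidin-1-yl on a saturated chain carbon, two bonds along the chain from an amide-type nitrogen, gives the first step that isolates a single change: a number 8.5 percentage points lower from compound 2 to compound 3 (within the scatter). Tying the two ethyl arms of the tertiary amine into one six-membered non-aromatic ring, with one more carbon in the group, therefore does not separate compound 3 from compound 2 on this read-out, and the size of the step gives no ranking of the two amines. No supporting measurement bears on this result, so the data offer no explanation for the printed step.

The compounds shown leave open whether a different ring at this place, such as pyrrolidin-1-yl or morpholin-4-yl, or an open-chain dimethylamino group, would give a step beyond the scatter. For the compounds shown here, they also leave open how a secondary or primary amine would read there with the rest of the molecule held fixed, since only tertiary amines carry numbers at this place so far.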